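Moving a Chlorine Around the Ring: Expected Half-Life

This account rests on a few compounds, and the source may have more. Where it says the series, first, only, none or still open, it means among the compounds named here.

Compound 1 `NS(=O)(=O)c1cc(-c2nnc(CNC(=O)c3ccccc3)o2)c(Cl)cc1SCc1ccccc1` gives 0.187 h in an ADME assay on microsomes from liver (Homo sapiens) for metabolic stability, read by LC-MS, using NADPH, tested at 5 uM; on this read-out higher numbers stand for a longer-lived compound and lower numbers for a shorter-lived compound.
Compound 2 `NS(=O)(=O)c1cc(-c2nnc(/C=C/c3cccc(Cl)c3)o2)c(Cl)cc1SCc1ccccc1` gives 0.352 h in this assay.

Both compounds share one core and differ only in the side chain on that core. Going by the values given here, compound 2 carries the higher of the two numbers, but the single step leading to it, a 1.9-fold higher number from compound 1 to compound 2 (0.27 log units; within the scatter), is within the scatter, so compound 2 cannot be separated from compound 1 on these data.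

Compound 3 `NS(=O)(=O)c1cc(-c2nnc(/C=C/c3ccc(Cl)cc3)o2)c(Cl)cc1SCc1ccccc1` is built from the same atoms as compound 2, joined differently: 4-chlorophenyl in place of 3-chlorophenyl on a double-bonded chain carbon bound to a double-bonded chain carbon. Among the compounds with values here, no measured step bears directly on this change. Within the data shown here, the only step available, a 1.9-fold higher number from compound 1 to compound 2 (0.27 log units; within the scatter), exchanges one side chain for another of quite a different kind and is itself within the scatter, so it offers no direction for a mere shift of the chlorine around its ring.

With nothing pointing up or down, the expectation for compound 3 in this assay is a step that stays within the scatter: a 1.0-fold lower number from compound 2 to compound 3 (0.00 log units; within the scatter). The estimate for compound 3 is 0.35 h, with a range from 0.17 h to 0.7 h.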

Compound 3, half-life: 0.207 h
Beside the measured number, compound 3's estimate is 1.7-fold (0.23 log units) above it; measured number inside the range.
By their numbers in this assay, from the lowest: compounds 1, 3 and 2 (each within the scatter of the next).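

In this assay, going by these compounds alone, the change from 3-chlorophenyl to 4-chlorophenyl on the double-bonded chain carbon is the first one here that alters only where the chlorine sits on its ring, and it gives a 1.7-fold lower number from compound 2 to compound 3 (0.23 log units; within the scatter) and so cannot be told apart from the ordinary variation between repeated measurements. The other new comparison, a 1.1-fold higher number from compound 1 to compound 3 (0.04 log units; within the scatter) and made by placing 2-(4-chlorophenyl)ethenyl where benzamidomethyl stood, is also too small to read as a real difference, so neither chlorine placement separates the styryl-type side chain from the benzamidomethyl one on these numbers. Nothing measured here offers an explanation for these small differences.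

All three compounds share the same core, and they still leave open whether any change at this position can move the half-life clearly beyond the scatter. A fluorine or a methoxy group in place of the chlorine, or an amine or a carboxylic acid on the far ring, would test whether this side chain has any real influence on how long the compound lasts in liver microsomes.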